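The source may report more compounds than this note shows. Statements on the series, on what has been measured and on what is new or still open speak of the compounds shown alone.

Of the compounds shown here, two have so far been tested in an ADME assay on Huh-7 cells (Homo sapiens) for cytotoxicity, read by MTT assay, with a stated time of 72 h; on this read-out lower numbers stand for higher toxicity in this test and higher numbers for lower toxicity in this test. Compound 1 (`CC(C)(C)c1ccc(NC(=O)/C=C/c2c[nH]c3ccccc23)cc1`) gives 10100 nM, and compound 2 (`CCOC(=O)/C(C)=C/c1c[nH]c2ccccc12`) gives 25300 nM. Compound 2 therefore holds the higher of the two numbers, by a gap beyond the usual scatter of repeated measurements, and so it is the less toxic of the pair in this test.

The next compound is compound 3 (`C/C(=C\c1c[nH]c2ccccc12)C(=O)NCCN(C)C`), which has (2-(dimethylamino)ethyl)amino in place of ethoxy on a carbonyl carbon. Going by the values given here, no measured pair differs by this change alone, so the data offer no direct guide to its effect. The only hint is weak: compound 1, at 10100 nM, also has a nitrogen-bearing group on a carbonyl carbon, but it differs from compound 2 in other ways as well.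

On this thin evidence, no change beyond the scatter is expected, with a slight lean towards a lower number. The estimated step is a 1.3-fold lower number from compound 2 to compound 3 (0.10 log units; within the scatter). For compound 3, the estimated value is 20000 nM, with an expected range from 8000 nM to 60000 nM.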

Compound 3, half-maximal cytotoxic concentration: > 100000 nM
Compound 3 gave a limit, no number (the forecaster's own chance of this, stated with the estimate: 15%); at least 5.0-fold (0.69 log units) between middle value and limit.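

Compounds 1 and 2 differ in more than one place, so they could not show how this carbonyl carbon responds to a single change; compound 2 and compound 3 now can. In this assay, compound 3 gives > 100000 nM, which is a limit and not a number. Placing (2-(dimethylamino)ethyl)amino in place of ethoxy on this carbonyl carbon gives an at least 3.9-fold higher number from compound 2 to compound 3 (0.59 log units; beyond the scatter), so this single change moves the read-out towards lower toxicity in this test by more than the usual scatter, and the true size of the step cannot be read because the result for compound 3 is a limit: the limit of > 100000 nM in this assay, at which 1 of the 3 values shown sits.

The compounds shown leave open which part of the entering group goes with this step, since the amide nitrogen and the dimethylamino end arrive together in a single change. A plain ethylamino group on the same carbonyl carbon would test the amide link without the dimethylamino end, while a longer chain ending in the same dimethylamino group would test whether the length of the chain matters.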